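This account rests on a few compounds, and the source may have more. Where it says the series, first, only, none or still open, it means among the compounds named here.

Measured compounds:
- Compound 2 `COc1cc2sn(CCCCCCN(C)Cc3ccccc3)c(=O)c2cc1OC`: in an assay on isolated protein for inhibition of Amine oxidase [flavin-containing] B (Homo sapiens), read by fluorescence, with a stated time of 30 min (a higher number here means a weaker inhibitor, a lower number a stronger inhibitor), compound 2 gives 13200 nM.
- Compound 1 `CCN(CCCCn1sc2cc(OC)c(OC)cc2c1=O)Cc1ccc(N(C)C)cc1`: in this assay compound 1 gives 18800 nM.
- Compound 3 `CCN(CCCCCCn1sc2cc(OC)c(OC)cc2c1=O)Cc1ccccc1`: in this assay compound 3 gives 20100 nM.

Compound 2 has the lowest of the three numbers, but its gaps to compound 1 and to compound 3 both lie within the usual scatter, so the three stand together and none can be called the stronger inhibitor. Within the data shown here, the only change between measured compounds that differ in one place, a 1.5-fold higher number from compound 2 to compound 3 (0.18 log units; within the scatter), is also within the scatter.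

Compound 4, `COc1ccccc1CN(C)CCCCCCn1sc2cc(OC)c(OC)cc2c1=O`, has not been measured. It differs from compound 2 in one place: methoxy in place of hydrogen on an aromatic carbon. Among the measured compounds shown here, no measured step alters the benzyl group itself, so none bears directly on this change. The step from compound 2 to compound 3 altered the group on the amine and left the number within the scatter, and compound 1, which carries a different group on its benzyl ring together with a shorter chain, also sits within the scatter of compound 2. Within these three compounds, changes around the amine and the benzyl group did not move the number beyond the scatter. The expectation is therefore a step of a 1.1-fold higher number from compound 2 to compound 4 (0.03 log units; within the scatter), no change beyond the scatter in this assay. Compound 4 is estimated at 14000 nM, with a range from 6000 nM to 32000 nM.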

Compound 4, half-maximal inhibitory concentration: 13700 nM
Compound 4: the middle estimate sits 1.0-fold (0.01 log units) above what was measured; measured number inside the range.
By their numbers in this assay, from the lowest: compounds 2, 4, 1 and 3 (each within the scatter of the next).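

In this assay the change of phenyl to 2-methoxyphenyl gives a 1.0-fold higher number from compound 2 to compound 4 (0.02 log units; within the scatter), the first step shown that alters the benzyl ring and nothing else. Compound 1 also carries a different benzyl ring, but its chain is shorter as well, so it could not show what a ring change does alone; here, a methoxy on an aromatic carbon, ortho to a large group, leaves the number within the scatter of compound 2. This holds for methoxy at this one place only, and nothing available explains the absence of a shift, since no measurement bears on it.

The compounds shown leave open whether a different group at this place, such as a hydroxyl, a chlorine, an amine or a carboxylic acid, would move the number beyond the scatter, and whether methoxy on another carbon of the ring would behave as it does here. With each of the four numbers within the scatter of the next, they also leave open which change to these compounds, if any, would clearly shift the number in this assay.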